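Trifluoromethoxy in Place of Fluoro: an Expected Step

The source may report more compounds than this note shows. Statements on the series, on what has been measured and on what is new or still open speak of the compounds shown alone.

Compound 1 `COc1ccc2c(=O)cc(/C=C/c3ccc(OC(F)(F)F)cc3)oc2c1`: > 40000 nM in a functional assay on SKHep cells (Homo sapiens) for antiproliferative activity, read by MTT assay, with a stated time of 12 h (on this read-out higher numbers stand for weaker inhibition and lower numbers for stronger inhibition), a limit of the assay rather than a number.
Compound 2 `COc1cc(OC)c2c(=O)cc(/C=C/c3ccc(F)cc3)oc2c1`: 29200 nM in this assay.

Going by the values given here, compound 2 holds the only number in this small set; the other value is a limit. Compound 1 sits at that limit, as the limit of > 40000 nM in this assay, at which 1 of the 2 values shown sits, shows, and so no ordering of the two can be read. Compound 3 `COc1cc(OC)c2c(=O)cc(/C=C/c3ccc(OC(F)(F)F)cc3)oc2c1` differs from compound 2 in one place: trifluoromethoxy in place of fluoro on an aromatic carbon. Among the compounds with values here, no measured pair shows this exact step. Compound 1, the other trifluoromethoxy compound here, reached only a limit, so the expected direction is toward weaker inhibition, by a step that may not exceed the usual scatter. Compound 3 is therefore estimated at 45000 nM, with a likely range from 15000 nM to 120000 nM. The expected step of a 1.5-fold higher number from compound 2 to compound 3 (0.19 log units; within the scatter) is small and uncertain.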

Compound 3, half-maximal inhibitory concentration: 12500 nM
Beside the measured number, compound 3's estimate is 3.6-fold (0.56 log units) above it; measured number below the stated range.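

In this assay, the larger trifluoromethoxy group is tolerated at this place, para to a large group, and putting it in place of fluoro gives a 2.3-fold lower number from compound 2 to compound 3 (0.37 log units; beyond the scatter). With trifluoromethoxy kept, methoxy in place of hydrogen on an aromatic carbon of the core gives an at least 3.2-fold lower number from compound 1 to compound 3 (0.50 log units; beyond the scatter), so the same group can sit in a compound with a measured value once the core changes in this one place. Compound 1 holds a limit and not a number, so the full size of that second step cannot be read: the limit of > 40000 nM in this assay, at which 1 of the 3 values shown sits.

On these data alone, whether the fluoro-to-trifluoromethoxy step would go the same way on the core of compound 1 stays open. So does how an amine, a carboxylic acid or a longer chain would behave at this same place.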